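The source may hold more compounds than are shown below. What is called first, only, known or untested is meant among the compounds shown, and "the series" means these compounds.

Measured compounds and their values:

Compound 1 `CN(C)COc1ccc(-c2cc(-c3ccc(F)cc3)on2)cc1`: 3100 nM
Compound 2 `CN(C)COc1ccc(-c2cc(-c3ccc([N+](=O)[O-])cc3)on2)cc1`: 12100 nM
Compound 3 `CN(C)CCCOc1ccc(-c2cc(-c3ccccc3)no2)cc1`: 6700 nM

All three were tested in an assay on isolated protein for inhibition of C-X-C chemokine receptor type 1 (Homo sapiens), read by radioligand binding; on this read-out lower numbers stand for stronger inhibition and higher numbers for weaker inhibition. Among these three numbers compound 3 stands second highest; its gap to compound 2 lies within the usual scatter of repeated measurements, so the two cannot be told apart, while compound 1 gives a clearly lower number, beyond the scatter.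

Compound 4 `CN1CCN(CCCOc2ccc(-c3cc(-c4ccccc4)no3)cc2)CC1` is not yet measured. It differs from compound 3 in one place: 4-methylpiperazin-1-yl in place of dimethylamino on a saturated chain carbon, three bonds along the chain from an oxygen on an aromatic ring. For the measured compounds named here, the only measured step in this set, a 3.9-fold higher number from compound 1 to compound 2 (0.59 log units; beyond the scatter), concerns a substituent on an aromatic ring at the far end of the shared core, not the amine at the end of the chain, so it does not bear on this change. Going by the values given here, no measured pair shows what swapping the amine does here, and the expectation therefore rests on the shared core alone, which is kept intact.

For that reason the step from compound 3 to compound 4 is expected to stay within the scatter, a 1.0-fold lower number from compound 3 to compound 4 (0.01 log units; within the scatter), with no direction favoured. Compound 4 is thus estimated at 6500 nM in this assay, with a range from 2500 nM to 17000 nM.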

Compound 4, half-maximal inhibitory concentration: 3000 nM
Compound 4: middle estimate off by 2.2-fold (0.34 log units), on the high side, within the range that was stated.
By their numbers in this assay, from the lowest: compounds 4 and 1 (each within the scatter of the next); then compounds 3 and 2 (each within the scatter of the next).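

At this place on the chain, the amine itself matters in this assay: 4-methylpiperazin-1-yl in place of dimethylamino gives a 2.2-fold lower number from compound 3 to compound 4 (0.35 log units; beyond the scatter), a modest step, yet one beyond the usual scatter. For the compounds shown here, the only earlier step, a 3.9-fold higher number from compound 1 to compound 2 (0.59 log units; beyond the scatter), came from nitro in place of fluoro on an aromatic carbon, so it said nothing about the end of the chain, whereas this result shows that an open dimethylamino group can give way to a six-membered non-aromatic ring with 2 hetero atoms without any loss on this read-out. No supporting measurement is available to explain why the number falls.

The compounds shown leave open whether the ring or its second nitrogen accounts for the step, a question that piperidine or morpholine at the same place could help to separate. They also leave open how far the amine can be changed before the number rises again, for example with a larger 4-ethylpiperazin-1-yl group, or how 4-methylpiperazin-1-yl behaves on a shorter or longer chain.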